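The source may hold more compounds than are shown below. What is called first, only, known or untested is meant among the compounds shown, and "the series" means these compounds.

Among the compounds with values here, compound 3 `O=C1/C(=C\Nc2cc(-c3ccco3)[nH]n2)C(c2ccccc2)=NN1c1ccccc1` has the lowest number of the three compounds measured so far in a functional assay on MDA-MB-361 cells (Homo sapiens) for antiproliferative activity, read by MTT assay, with a stated time of 72 h; a lower number here means a stronger inhibitor, a higher number a weaker inhibitor. In this assay compound 3 gives 13400 nM. Its nearest neighbour is compound 2 `CCOC(=O)c1c[nH]nc1N/C=C1\C(=O)N(c2ccccc2)N=C1c1ccccc1`, which in this assay gives 24700 nM; the difference a 1.8-fold lower number from compound 2 to compound 3 (0.27 log units; within the scatter) lies within the scatter. Furthest away is compound 1 `O=C1NN=C(c2ccccc2)/C1=C/Nc1cc[nH]n1`, which in this assay gives 95300 nM, a gap that lies beyond the scatter; compound 1 differs from compound 3 in two places, so its value gives only a rough hint.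

Compound 4 `O=C1/C(=C\Nc2cc[nH]n2)C(c2ccccc2)=NN1c1ccccc1` differs from compound 3 by hydrogen in place of furan-2-yl on an aromatic carbon, on an aromatic carbon of the five-membered aromatic ring with two nitrogen, next to the ring nitrogen. Within the data shown here, no measured step addresses exactly this change. Among the measured compounds shown here, the only single-place step, from compound 2 to compound 3, swapped one group for another on that ring and stayed within the scatter, while compound 1, which lacks the furan-2-yl and more, shows a weaker number. A modestly higher number for compound 4 is therefore expected, a step of a 2.4-fold higher number from compound 3 to compound 4 (0.38 log units; beyond the scatter). Compound 4 is estimated at 32000 nM, with a range from 10000 nM to 100000 nM.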

Compound 4, half-maximal inhibitory concentration: 51000 nM
Beside the measured number, compound 4's estimate is 1.6-fold (0.20 log units) below it; low and high end bracket the measured number.
By their numbers in this assay, from the lowest: compounds 3 and 2 (each within the scatter of the next); then compounds 4 and 1 (each within the scatter of the next).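

With the furan-2-yl replaced by hydrogen on this aromatic carbon, next to the ring nitrogen, this assay gives a 3.8-fold higher number from compound 3 to compound 4 (0.58 log units; beyond the scatter), so a group at this place does affect the number. Loss of the ethoxycarbonyl gives a 2.1-fold higher number from compound 2 to compound 4 (0.31 log units; beyond the scatter), which places compound 4, with its unsubstituted 1H-pyrazol-3-yl, above both substituted compounds, while compound 2 and compound 3 remain within the scatter of each other. Phenyl in place of hydrogen on the amide-type nitrogen gives a 1.9-fold lower number from compound 1 to compound 4 (0.27 log units; within the scatter), so that change shows no effect beyond the scatter.

No measurement shown here explains why these substituents lower the number. As far as these compounds go, whether a methyl, an amine or a phenyl on this aromatic carbon would match the furan-2-yl remains open.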